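Changing the Aryl Group on the Ring Nitrogen

The compounds below may be only part of what the source reports. "The series", "measured", "known", "first", "only" and "open" are said of these compounds alone.

Among the measured compounds shown here, compound 2 `COc1ccccc1-n1nc(-c2ccc(C(F)(F)F)cc2O)nc1-c1ccccc1O` is one of two compounds so far tested in a functional assay on PC-12 cells (Rattus norvegicus) for cytotoxicity, read by MTT assay, with stated times of 2 h and 24 h, tested at 1 uM (a higher number here means a stronger effect of the compound at the concentration tested, a lower number a weaker effect), where compound 2 gives 70.7%. Its number is the higher of the two shown, but the other compound, compound 1 `CCc1ccc(-n2nc(-c3ccc(C(F)(F)F)cc3O)nc2-c2ccccc2O)cc1`, gives 64.4%, and the step of a number 6.3 percentage points higher from compound 1 to compound 2 (within the scatter) lies within the scatter, so the two cannot be told apart. Compound 3 `Cc1ccc(-n2nc(-c3ccc(C(F)(F)F)cc3O)nc2-c2ccccc2O)c(C)c1` has not yet been measured; it differs from compound 2 by 2,4-dimethylphenyl in place of 2-methoxyphenyl on an aromatic nitrogen. For the measured compounds named here, the only measured step that bears on this exchange also swapped the group on the same aromatic nitrogen and came out at a number 6.3 percentage points higher from compound 1 to compound 2 (within the scatter), within the scatter. A change at this place has so far moved the read-out little, and for compound 3 a step of a number 3.7 percentage points lower from compound 2 to compound 3 (within the scatter) is expected, none beyond the scatter. Compound 3 is estimated to give 67%, with a range from 55% to 78%.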

Compound 3, a percentage reported as activity, at one concentration (the size of the read-out at that concentration, not a potency): 73.7%
For compound 3 the middle estimate is 6.7 percentage points below the measured one; the measured number falls inside the stated range.
By their numbers in this assay, from the lowest: compounds 1, 2 and 3 (each within the scatter of the next).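

In this assay, putting 2,4-dimethylphenyl, with no hydrogen-bond acceptor, in place of 2-methoxyphenyl, with one, gives a number 3 percentage points higher from compound 2 to compound 3 (within the scatter) and so shows that losing the oxygen at this position leaves no readable mark on the result. The comparison with 4-ethylphenyl gives a number 9.3 percentage points higher from compound 1 to compound 3 (within the scatter) and places all three groups on the aromatic nitrogen within reach of one another, so they cannot be told apart here. No measurement at hand explains why these groups give such similar numbers.

On these data alone, all three groups are six-membered aromatic rings of carbon only, so it remains open whether an amine, a carboxylic acid or a longer alkyl chain on this nitrogen would move the number beyond the scatter. The compounds also leave open what would happen if the trifluoromethyl group or either hydroxyl group on the shared core were changed.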